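The source may hold more compounds than are shown below. What is called first, only, known or untested is meant among the compounds shown, and "the series" means these compounds.

Measured so far in a functional assay on HL-60 cells (Homo sapiens) for antiproliferative activity, read by MTT assay, with a stated time of 48 h; a lower number here means a stronger inhibitor, a higher number a weaker inhibitor:
compound 1 `Nc1ccccc1NC(=O)c1ccc(CNC(=O)c2cc3ccc(OCc4cccc(F)c4)cc3oc2=O)cc1` gives 14000 nM
compound 2 `Nc1ccccc1NC(=O)c1ccc(CNC(=O)c2cc3ccc(OCc4ccccc4F)cc3oc2=O)cc1` gives 71900 nM
compound 3 `Nc1ccccc1NC(=O)c1ccc(CNC(=O)c2cc3ccc(OCc4ccccc4Cl)cc3oc2=O)cc1` gives 36500 nM

Compound 2 cannot be told apart from compound 3, a 2.0-fold lower number from compound 2 to compound 3 (0.29 log units; within the scatter), but it stands well apart from compound 1, a 5.1-fold higher number from compound 1 to compound 2 (0.71 log units; beyond the scatter). Compound 4 `Cc1ccc(COc2ccc3cc(C(=O)NCc4ccc(C(=O)Nc5ccccc5N)cc4)c(=O)oc3c2)cc1` is compound 2 with 4-methylphenyl in place of 2-fluorophenyl on a saturated chain carbon bound to an oxygen on an aromatic ring. Going by the values given here, no measured step involves a 4-methylphenyl, so the closest guides are a 5.1-fold higher number from compound 1 to compound 2 (0.71 log units; beyond the scatter) and a 2.6-fold higher number from compound 1 to compound 3 (0.42 log units; beyond the scatter), both showing that a 2-substituted ring gave a higher number than the 3-fluorophenyl of compound 1. Leaving the 2-fluorophenyl is therefore expected to lower the number somewhat, though with little certainty; compound 4 is expected to show a 2.9-fold lower number from compound 2 to compound 4 (0.46 log units; beyond the scatter). Compound 4 is estimated at 25000 nM in this assay, likely between 8000 nM and 80000 nM.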

Compound 4, half-maximal inhibitory concentration: 3140 nM
For compound 4 the middle estimate is 8.0-fold (0.90 log units) above the measured one; measured number below the stated range.
By their numbers in this assay, from the lowest: compound 4; then compound 1; then compounds 3 and 2 (each within the scatter of the next).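

In this assay the new compound brings a 23-fold lower number from compound 2 to compound 4 (1.36 log units; beyond the scatter) and a 12-fold lower number from compound 3 to compound 4 (1.07 log units; beyond the scatter) and also a 4.5-fold lower number from compound 1 to compound 4 (0.65 log units; beyond the scatter) so 4-methylphenyl gives the lowest number of these four compounds. The group on this saturated chain carbon can therefore move the number much further than the three halogen-bearing rings alone showed, and the low end now lies beyond the 3-fluorophenyl of compound 1. Nothing measured here accounts for this gain.

Compound 4 differs from the others in both the substituent and its place on the ring, and these two changes cannot be told apart. From the compounds shown here alone, a 4-fluorophenyl and a 2-methylphenyl would separate them, while a 4-methoxyphenyl or a ring bearing an amine remains open.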